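Working notes: propargyloxy in place of butoxycarbonyl

This account rests on a few compounds, and the source may have more. Where it says the series, first, only, none or still open, it means among the compounds named here.

Measured so far in a functional assay on the whole organism for inhibition, with Scenedesmus acutus as the target; a lower number here means a stronger inhibitor, a higher number a weaker inhibitor
- compound 1 `COC(=O)c1cc(N2C(=O)C3=C(CCCC3)C2=O)c(F)cc1Cl` gives 67.6 nM
- compound 2 `CC(C)OC(=O)c1cc(N2C(=O)C3=C(CCCC3)C2=O)c(F)cc1Cl` gives 13.8 nM
- compound 3 `CCCCOC(=O)c1cc(N2C(=O)C3=C(CCCC3)C2=O)c(F)cc1Cl` gives 126 nM

Compound 3 stands at the high-number end of the three, level with compound 1 within the scatter (a 1.9-fold higher number from compound 1 to compound 3 (0.27 log units; within the scatter)). Compound 4 `C#CCOc1cc(N2C(=O)C3=C(CCCC3)C2=O)c(F)cc1Cl` carries propargyloxy in place of butoxycarbonyl on an aromatic carbon. Among the measured compounds shown here, no measured step replaces the ester itself, so the evidence is indirect. Changes on the ester oxygen alone gave a 4.9-fold lower number from compound 1 to compound 2 (0.69 log units; beyond the scatter) and a 9.1-fold higher number from compound 2 to compound 3 (0.96 log units; beyond the scatter), and these modest steps set the expected scale. With compound 3 at 126 nM and most of the measured range below it, a lower number is expected in this assay (a 6.3-fold lower number from compound 3 to compound 4 (0.80 log units; beyond the scatter)). Compound 4 is estimated at 20 nM (range 4 nM to 90 nM).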

Compound 4, half-maximal inhibitory concentration: 15.9 nM
Compound 4: the middle estimate sits 1.3-fold (0.10 log units) above what was measured; low and high end bracket the measured number.
By their numbers in this assay, from the lowest: compounds 2 and 4 (each within the scatter of the next); then compounds 1 and 3 (each within the scatter of the next).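

In this assay the ester is not needed at this position on the aromatic carbon: a 7.9-fold lower number from compound 3 to compound 4 (0.90 log units; beyond the scatter) and a 4.3-fold lower number from compound 1 to compound 4 (0.63 log units; beyond the scatter). Propargyloxy, which has no carbonyl, also matches the best ester, as a 1.2-fold higher number from compound 2 to compound 4 (0.06 log units; within the scatter). No available evidence accounts for this replacement.

From the compounds shown here alone, whether the triple bond matters remains open, as a propoxy or allyloxy group at this position would test. So does the role of the ether oxygen, which a propargylamino group in its place would address.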